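Amide aryl swap to 4-cyanophenyl in the benzimidazole series

The compounds below may be only part of what the source reports. "The series", "measured", "known", "first", "only" and "open" are said of these compounds alone.

The series shares a benzimidazolylmethyl-substituted benzylamide core and varies the group on the carbonyl carbon. Compound 1 `O=C(NCc1cccc(Cn2cnc3ccccc32)c1)c1cc(Br)c[nH]1` carries a 4-bromo-1H-pyrrol-2-yl group and in an assay on HeLa cells for inhibition of Indoleamine 2,3-dioxygenase 1 (Homo sapiens), read by HPLC, with a stated time of 48 h (on this read-out lower numbers stand for stronger inhibition and higher numbers for weaker inhibition), compound 1 gives 64 nM. Within the data shown here, compound 2 `O=C(NCc1cccc(Cn2cnc3ccccc32)c1)c1cc2ccccc2[nH]1` carries 1H-indol-2-yl and in this assay compound 2 gives 72 nM, the higher of the two numbers so far, with a 1.1-fold higher number from compound 1 to compound 2 (0.05 log units; within the scatter), so the two five-membered nitrogen heterocycles are indistinguishable on these data.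

Compound 3 `N#Cc1ccc(C(=O)NCc2cccc(Cn3cnc4ccccc43)c2)cc1` makes a different kind of change: 4-cyanophenyl in place of 1H-indol-2-yl on a carbonyl carbon. Among the measured compounds shown here, no measured step covers the loss of the ring hydrogen-bond donor and the move to a six-membered carbocycle bearing a nitrile; the one step recorded, from a bromopyrrole to an indole, stayed within the scatter and bears on this change only loosely. The expectation is therefore uncertain and leans to a weaker number, with an estimated step of a 2.1-fold higher number from compound 2 to compound 3 (0.32 log units; beyond the scatter) in this assay. For compound 3 the estimate in this assay is 150 nM, in the range 50 nM to 500 nM.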

Compound 3, half-maximal inhibitory concentration: 90 nM
Compound 3: the middle estimate sits 1.7-fold (0.22 log units) above what was measured; measured number inside the range.
By their numbers in this assay, from the lowest: compounds 1, 2 and 3 (each within the scatter of the next).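

In this assay, replacing 1H-indol-2-yl with 4-cyanophenyl on the carbonyl carbon gives a 1.3-fold higher number from compound 2 to compound 3 (0.10 log units; within the scatter), and the comparison with the 4-bromo-1H-pyrrol-2-yl group gives a 1.4-fold higher number from compound 1 to compound 3 (0.15 log units; within the scatter). Among these compounds, earlier, only two five-membered nitrogen heterocycles had been compared; this position now also accepts a six-membered aromatic ring of carbon only, bearing a nitrile and lacking the hydrogen-bond donor of 1H-indol-2-yl, with no step among the three compounds beyond the scatter, so on these compounds that donor is not required to keep the number in this range. No supporting measurement accounts for the three groups reading alike.

The compounds shown leave open how much the nitrile contributes in its own right, which a plain phenyl group on the same carbonyl carbon would address, and whether a 4-carboxyphenyl group or a saturated amine such as piperidin-4-yl would separate from these three. They also leave open whether this flat response holds with any change to the shared core, which stays constant throughout.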